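This account rests on a few compounds, and the source may have more. Where it says the series, first, only, none or still open, it means among the compounds named here.

Working notes on the hydrazone series. Within the data shown here, the parent, compound 1 `O=C(N/N=C/c1ccccc1)c1cnccn1`, is the unsubstituted member; in an ADME assay on J774 cells (Mus musculus) for cytotoxicity, read by MTT assay, with a stated time of 48 h, tested at 100 ug/mL (on this read-out lower numbers stand for a stronger effect and higher numbers for a weaker effect at the one concentration tested), compound 1 gives 75%, the second highest of the three numbers so far. Compound 2 `O=C(N/N=C/c1cccc(F)c1)c1cnccn1` gives 46%, and compound 3 `O=C(N/N=C/c1cccc(O)c1)c1cnccn1` gives 100%. The two measured steps from the parent both put a single group on the aromatic ring: a number 29 percentage points lower from compound 1 to compound 2 (beyond the scatter), whereas a number 25 percentage points higher from compound 1 to compound 3 (beyond the scatter); between the two substituted members, a number 54 percentage points higher from compound 2 to compound 3 (beyond the scatter). Compound 4 `CN(C)c1ccc(/C=N/NC(=O)c2cnccn2)cc1` is the next member, differing from compound 1 by dimethylamino in place of hydrogen on an aromatic carbon. Among the measured compounds shown here, no dimethylamino step is measured, and the two aromatic substitutions bear on it only loosely, pointing in opposite directions at modest size. A change of no more than modest size is therefore expected for compound 4, with no firm direction, a number 3 percentage points higher from compound 1 to compound 4 (within the scatter); compound 4 is estimated at 78%, between 50% and 100% in this assay.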

Compound 4, a percentage reported as activity, at one concentration (the size of the read-out at that concentration, not a potency): 87%
Compound 4: the middle estimate sits 9 percentage points below what was measured; the measured number falls inside the stated range.
By their numbers in this assay, from the lowest: compound 2; then compound 1; then compound 4; then compound 3.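

In this assay, among these compounds, dimethylamino on the aromatic carbon para to a large group gives a number 12 percentage points higher from compound 1 to compound 4 (beyond the scatter), the first measured step at this place on the ring. A modest rise of this kind runs with the hydroxy step from the parent and against the fluoro step, although those two groups stand elsewhere on the ring. No measurement at hand accounts for this step. Going by these compounds, whether a primary amine or a carboxylic acid at this place would move the number the same way stays open. Also open, on these data alone, is how dimethylamino would behave at the ring place held by fluoro in compound 2 and hydroxy in compound 3.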